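Thiophene in Place of the Aryl Urea Terminus in Ret Inhibitors

A few compounds are considered here, and "the series" means these few. Any claim that something is new, unique, unknown or untested is made for them only; others in the source may bear on it.

Measured compounds:
compound 1 `O=C(Nc1ccc(Nc2ncnc3c2OCCN3)cc1)Nc1ccc(C(F)(F)F)cc1`: 306 nM
compound 2 `COc1ccc(NC(=O)Nc2ccc(Nc3ncnc4c3OCCN4)cc2)cc1`: 227 nM
compound 3 `Cc1ccc(F)c(NC(=O)Nc2ccc(Nc3ncnc4c3OCCN4)cc2)c1`: 1470 nM

In an assay on isolated protein for inhibition of proto-oncogene tyrosine-protein kinase receptor Ret (Homo sapiens), read by 33P incorporation, with stated times of 15 min and 40 min (on this read-out higher numbers stand for weaker inhibition and lower numbers for stronger inhibition), compound 1 gives 306 nM, the second highest of the three numbers. The nearest neighbour is shown by a 1.3-fold lower number from compound 1 to compound 2 (0.13 log units; within the scatter), the furthest by a 4.8-fold higher number from compound 1 to compound 3 (0.68 log units; beyond the scatter). Compound 4 `O=C(Nc1ccc(Nc2ncnc3c2OCCN3)cc1)Nc1cccs1` differs from compound 1 in one place: thiophen-2-yl in place of 4-(trifluoromethyl)phenyl on an amide-type nitrogen. For the measured compounds named here, two measured steps bear on this. a 1.3-fold lower number from compound 1 to compound 2 (0.13 log units; within the scatter) shows that exchanging one para group for another leaves the number unchanged within the scatter, whereas a 4.8-fold higher number from compound 1 to compound 3 (0.68 log units; beyond the scatter) and a 6.5-fold higher number from compound 2 to compound 3 (0.81 log units; beyond the scatter) show that a differently substituted phenyl ring costs a modest amount. Going by the values given here, no measured step removes the six-membered ring itself, so the thiophene is a larger departure than either. Compound 4 is therefore expected to give 600 nM, with a range from 200 nM to 1800 nM. The expected step is a 2.0-fold higher number from compound 1 to compound 4 (0.29 log units; within the scatter), modestly weaker than compound 1.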

Compound 4, half-maximal inhibitory concentration: > 10000 nM
Compound 4: a limit, no number; the forecaster's own chance of this, stated with the estimate: 5%; at least 16-fold (1.22 log units) between middle value and limit.
By their numbers in this assay, from the lowest: compounds 2 and 1 (each within the scatter of the next); then compound 3. At a limit, above all of these: compound 4.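

In this assay compound 4 stands at a limit, not a number: the limit of > 10000 nM in this assay, at which 1 of the 4 values shown sits. Putting thiophen-2-yl on this amide-type nitrogen gives an at least 32-fold higher number from compound 1 to compound 4 (1.51 log units; beyond the scatter), an at least 44-fold higher number from compound 2 to compound 4 (1.64 log units; beyond the scatter) and an at least 6.8-fold higher number from compound 3 to compound 4 (0.83 log units; beyond the scatter). The earlier compounds shown here varied only the substituents on a phenyl ring, whereas this change shows that replacing the ring itself can matter at this position.

The compounds shown do not separate the five-membered ring, the sulfur and the lack of a substituent on the ring. Going by these compounds, an unsubstituted phenyl, a furan-2-yl and a thiophene carrying methoxy or trifluoromethyl are not among them, so that question stays open.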